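This account rests on a few compounds, and the source may have more. Where it says the series, first, only, none or still open, it means among the compounds named here.

Measured compounds in a functional assay on MCF7 cells (Homo sapiens) for antiproliferative activity; a higher number here means a weaker inhibitor, a lower number a stronger inhibitor:
compound 1, `CC(=O)Oc1ccc(C(=O)Nc2cc3ccc(OCC4CCCN(C)C4)c(C)c3oc2=O)cc1CC=C(C)C`: 1650 nM
compound 2, `CC(=O)Oc1ccc(C(=O)Nc2cc3ccc(OCCC4CCCCN4)c(C)c3oc2=O)cc1CC=C(C)C`: 710 nM
compound 3, `CC(C)=CCc1cc(C(=O)Nc2cc3ccc(OCCCNC(C)C)c(C)c3oc2=O)ccc1O`: 740 nM

Compound 3 gives the second highest of the three numbers; its value and that of compound 2 lie within the scatter of each other, while compound 1 stands beyond the scatter with a higher number. Compound 4 is `CC(C)=CCc1cc(C(=O)Nc2cc3ccc(OCCCN[C@H](C)c4ccccc4)c(C)c3oc2=O)ccc1O`. It differs from compound 3 in one place: 1-phenylethyl in place of isopropyl on an amine nitrogen. Among the compounds with values here, the only measured step, a 2.3-fold lower number from compound 1 to compound 2 (0.37 log units; beyond the scatter), also changes the amine-bearing end of the chain on the oxygen of the aromatic ring, but it exchanges one cyclic amine for another and does not replace a substituent on the nitrogen, so it bears on the present change only loosely, showing merely that a change in this part of the molecule gave a modest shift. Within the data shown here, no measured pair shows 1-phenylethyl in place of isopropyl on an amine nitrogen. The expected step is therefore small, a 1.2-fold lower number from compound 3 to compound 4 (0.09 log units; within the scatter), with wide uncertainty. Compound 4 is estimated at 600 nM (range 250 nM to 1500 nM).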

Compound 4, half-maximal inhibitory concentration: 1450 nM
Beside the measured number, compound 4's estimate is 2.4-fold (0.38 log units) below it; measured number inside the range.
By their numbers in this assay, from the lowest: compounds 2, 3, 4 and 1 (each within the scatter of the next, the first and the last beyond it).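

In this assay, 1-phenylethyl in place of isopropyl on an amine nitrogen gives a 2.0-fold higher number from compound 3 to compound 4 (0.29 log units; within the scatter). This position therefore accepts a six-membered aromatic ring of carbon and a defined stereocentre in the group on the nitrogen, with no step beyond the scatter, which the earlier exchange of one cyclic amine for another could not show. No supporting data on hand explain this result.

The compounds shown leave open whether the opposite configuration of 1-phenylethyl would read the same as compound 4, and whether benzyl or a 2-phenylethyl group on the same nitrogen would stay within the scatter of compound 3. As far as these compounds go, an unsubstituted primary amine at the end of the chain also remains open as a reference for both groups.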